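This account rests on a few compounds, and the source may have more. Where it says the series, first, only, none or still open, it means among the compounds named here.

Measured compounds:
- Compound 1, `CC(C(=O)NCc1ccc(C(F)(F)F)nc1NC1CCCCC1)c1ccc(NS(C)(=O)=O)c(F)c1`: 20.4 nM
- Compound 2, `Cc1ccc(CC2CCN(c3nc(C(F)(F)F)ccc3CNC(=O)C(C)c3ccc(NS(C)(=O)=O)c(F)c3)CC2)cc1`: 0.2 nM

Both compounds were tested in a functional assay on CHO-K1 cells for antagonist activity at transient receptor potential cation channel subfamily V member 1 (Homo sapiens), read by FLIPR; on this read-out higher numbers stand for weaker inhibition and lower numbers for stronger inhibition. Compound 2 stands at the lowest number of the two, and the gap to compound 1 is far beyond the usual scatter of repeated measurements, so compound 2 is clearly the stronger inhibitor of the pair.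

Compound 3, `CC(=O)OC1CCN(c2nc(C(F)(F)F)ccc2CNC(=O)C(C)c2ccc(NS(C)(=O)=O)c(F)c2)CC1`, has not yet been measured. It differs from compound 2 in one place: acetoxy in place of 4-methylbenzyl on a saturated ring carbon. A large ring-bearing group is thus exchanged for a small oxygen-bearing one on the saturated ring.

Among the measured compounds shown here, no measured pair shows this kind of change, so the expectation rests on the two numbers alone. The step of a 25-fold higher number from compound 2 to compound 3 (1.40 log units; beyond the scatter) is expected to be a clear loss of potency, beyond the scatter. Compound 3 is estimated at 5 nM, with a likely range from 0.8 nM to 40 nM.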

Compound 3, inhibition constant: 4 nM
Compound 3: middle estimate off by 1.3-fold (0.10 log units), on the high side; the range from low to high includes it.
By their numbers in this assay, from the lowest: compound 2; then compound 3; then compound 1.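

In this assay, the change at this saturated ring carbon gives a 20-fold higher number from compound 2 to compound 3 (1.30 log units; beyond the scatter) and so shows that potency depends strongly on what the carbon carries. Acetoxy still keeps much of the activity, however: with 4-acetoxypiperidin-1-yl in place of cyclohexylamino on an aromatic carbon, the step is a 5.1-fold lower number from compound 1 to compound 3 (0.71 log units; beyond the scatter) and still favours the acetoxy compound. Nothing measured here explains either step.

Acetoxy differs from 4-methylbenzyl at once in size, in lacking a ring and in carrying oxygen, so these compounds cannot show which difference matters. A hydroxyl group, an amine or a plain phenyl ring on the same carbon would help to separate these possibilities.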